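The compounds below may be only part of what the source reports. "The series", "measured", "known", "first", "only" and "open" are said of these compounds alone.

Compound 2, with the structure `CCOC(=O)CCCCCOc1cccc(CN(C(=O)c2ccc(-c3cccc(OC(C)C)c3)cc2)C(C)C)c1`, is a near relative of compound 1, whose structure is `CCOC(=O)CCCCCOc1cccc(CN(C(=O)c2ccc(-c3cccc(C(C)=O)c3)cc2)C(C)C)c1`. Both were tested in an ADME assay on HepG2 cells (Homo sapiens) for cytotoxicity, read by CellTiter-Glo and resazurin assay, with a stated time of 72 h; on this read-out lower numbers stand for an effect already at smaller amounts and higher numbers for an effect only at larger amounts of compound. In this assay compound 1 reaches only the assay limit of > 26000 nM. Compound 2 likewise stops at the assay limit of > 26000 nM. Accordingly, the step that the two limits leave unreadable from compound 1 to compound 2 cannot be read, and what the two results share is summed up in the limit of > 26000 nM in this assay, at which 2 of the 2 values shown sit. Compound 2 therefore stands at the limit and nowhere above or below it on the numbers shown.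

Compound 3, with the structure `CCOC(=O)CCCCCOc1cccc(CN(C(=O)c2ccc(-c3cccc(Oc4ccccc4)c3)cc2)C(C)C)c1`, differs from compound 2 by phenyl in place of isopropyl on an oxygen on an aromatic ring. Among the measured compounds shown here, the only measured step that bears on this change is the unreadable one from compound 1 to compound 2, which offers no size and no direction. With both neighbours sitting at the limit, the expectation for compound 3 is that it too remains at or past the limit, so that the step that the limit leaves unreadable from compound 2 to compound 3 is expected to lie within the scatter. Compound 3 is therefore estimated at 40000 nM, within 20000 nM to 120000 nM.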

Compound 3, half-maximal effective concentration: > 26000 nM
Compound 3: no number, only a limit; the forecaster's own chance of this, stated with the estimate: 80%; the middle value does not contradict the limit.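

In this assay compound 3 gives > 26000 nM as a limit of the assay and not a number. Among the compounds shown here, no step can therefore be read from compound 2 to compound 3, or from compound 1 to compound 3. The compounds shown leave open whether any of these changes on the aromatic ring alters the cytotoxicity, and where their true values lie.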